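Extending the amide chain on a thiadiazole glycoside

A few compounds are considered here, and "the series" means these few. Any claim that something is new, unique, unknown or untested is made for them only; others in the source may bear on it.

Measured so far:
- compound 1, `CCCCCCCCCC(=O)Nc1nnc(S[C@@H]2O[C@H](CO)[C@H](O)[C@H](O)[C@H]2O)s1`: 25900 nM
- compound 2, `CCCCCCCC(=O)Nc1nnc(S[C@@H]2O[C@H](CO)[C@H](O)[C@H](O)[C@H]2O)s1`: 50800 nM

In a functional assay on HeLa cells (Homo sapiens) for cytotoxicity, read by MTT assay, with a stated time of 24 h (a lower number here means a stronger inhibitor, a higher number a weaker inhibitor), compound 2 gives the highest of the two numbers; its nearest neighbour is compound 1, and the step of a 2.0-fold higher number from compound 1 to compound 2 (0.29 log units; within the scatter) lies within the usual scatter. Compound 3, `CCCCCCCC/C=C\CCCCCCCC(=O)Nc1nnc(S[C@@H]2O[C@H](CO)[C@H](O)[C@H](O)[C@H]2O)s1`, carries the change (dec-1-en-1-yl in place of hydrogen on a saturated chain carbon, seven bonds along the chain from a carbonyl carbon), so the same chain is carried on by dec-1-en-1-yl with one double bond outside aromatic rings. Going by the values given here, only one measured step bears on this: a 2.0-fold higher number from compound 1 to compound 2 (0.29 log units; within the scatter), a small move toward a lower number as the chain grows. That hints that a longer chain may give a lower number in this assay, but one step within the scatter is weak ground, and the added piece is far larger than ethyl. Compound 3 is therefore expected near 15000 nM, within 4000 nM to 60000 nM. The step of a 3.4-fold lower number from compound 2 to compound 3 (0.53 log units; beyond the scatter) is the expected outcome.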

Compound 3, half-maximal inhibitory concentration: 8800 nM
Compound 3: middle estimate off by 1.7-fold (0.23 log units), on the high side; the range from low to high includes it.
By their numbers in this assay, from the lowest: compound 3; then compounds 1 and 2 (each within the scatter of the next).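

Seen in this assay, the earlier change at this position gave only a 2.0-fold higher number from compound 1 to compound 2 (0.29 log units; within the scatter), so it could not show that the chain matters. Dec-1-en-1-yl on a saturated chain carbon, seven bonds along the chain from a carbonyl carbon, gives the first clear shift, with a 5.8-fold lower number from compound 2 to compound 3 (0.76 log units; beyond the scatter) and, when it replaces ethyl, a 2.9-fold lower number from compound 1 to compound 3 (0.47 log units; beyond the scatter), so this position accepts a far larger group with a double bond and the number still falls. No measurement here explains that fall.

Compound 3 brings a longer chain and a double bond together, leaving open which of the two goes with the lower number, a question that a fully saturated chain of the same length could address. Also open, going by these compounds, is how an amine or a carboxylic acid at the far end of the chain would read in this assay.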